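A Methoxy Step Repeated on a Related Compound

The compounds below may be only part of what the source reports. "The series", "measured", "known", "first", "only" and "open" are said of these compounds alone.

In a functional assay on Hs-578T cells (Homo sapiens) for inhibition, read by sulforhodamine B assay, with a stated time of 48 h (a higher number here means a weaker inhibitor of growth, a lower number a stronger inhibitor of growth), three compounds have been measured:
compound 1, `COc1ccc(-c2cc(/C=C/C(=O)c3ccc(N)cc3)[nH]n2)cc1`: 4040 nM
compound 2, `COc1ccc(C(=O)/C=C/c2cc(-c3cc(OC)c(OC)c(OC)c3)n[nH]2)cc1OC`: 2570 nM
compound 3, `COc1ccc(-c2cc(/C=C/C(=O)c3ccc(N)cc3)[nH]n2)cc1OC`: 6570 nM

Compound 3 arises from compound 1 by methoxy in place of hydrogen on an aromatic carbon, and in this assay this gave a 1.6-fold higher number from compound 1 to compound 3 (0.21 log units; within the scatter). Compound 2 gives the lowest of the three numbers, but its gap to compound 1 is within the scatter, while its gap to compound 3 is beyond it. The difference between the cores of compound 1 and compound 2 is not broken down here.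

Compound 4, `COc1cc(C(=O)/C=C/c2cc(-c3cc(OC)c(OC)c(OC)c3)n[nH]2)cc(OC)c1OC`, is not yet measured. It arises from compound 2 by methoxy in place of hydrogen on an aromatic carbon. This is the same kind of change as that from compound 1 to compound 3, though the surroundings differ: in compound 4 the entering methoxy is also meta to a methoxy group, which is not the case in compound 3. Because a 1.6-fold higher number from compound 1 to compound 3 (0.21 log units; within the scatter) lay within the scatter, only a small step is expected here as well. From compound 2 the expected step in this assay is a 1.5-fold higher number from compound 2 to compound 4 (0.17 log units; within the scatter). Compound 4 is therefore estimated at 3800 nM, with a likely range from 1500 nM to 10000 nM.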

Compound 4, concentration for 50% growth inhibition: 2680 nM
Beside the measured number, compound 4's estimate is 1.4-fold (0.15 log units) above it, and the stated range covers the measured number.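

In this assay, methoxy in place of hydrogen on an aromatic carbon gave a 1.0-fold higher number from compound 2 to compound 4 (0.02 log units; within the scatter). Set beside the earlier case, the change reads alike on the two cores: the same change on two cores in this assay, a 1.6-fold higher number (0.21 log units; within the scatter) from compound 1 to compound 3 and a 1.0-fold higher number (0.02 log units; within the scatter) from compound 2 to compound 4, 1.6-fold (0.19 log units) apart, within the scatter of two such steps. Going by these compounds alone, this shows that the step stayed small on both cores and that the two steps cannot be told apart, but it rests on only two pairs, neither of which moved beyond the scatter, and it does not show that the same would hold on a third core, at another place on a ring, or in a different assay.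

The compounds shown leave open whether a group other than methoxy, such as a hydroxyl, a chlorine or a carboxylic acid, would also leave the number within the scatter at the same place. From the compounds shown here alone, it also remains open whether a longer chain, such as ethoxy, would behave as methoxy does on either core.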